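This account rests on a few compounds, and the source may have more. Where it says the series, first, only, none or still open, it means among the compounds named here.

Working notes on a small urea series tested in a functional assay on NCI-H226 cells (Homo sapiens) for inhibition, read by MTT assay, with a stated time of 48 h, tested at 10 uM; a lower number here means less inhibition, a higher number more inhibition at the concentration tested (going by the name of the read-out).

Of the compounds shown here, three have numbers so far. Compound 1, `COc1cc(NC(=O)Nc2cc(Nc3ccc(C(C)(C)C)cc3)ncn2)cc(OC)c1`, gives 47.7% in this assay. Compound 2, `Cc1ccc(Nc2cc(NC(=O)Nc3c(Cl)cccc3Cl)ncn2)cc1F`, gives 40.7%. Compound 3, `CCc1ccc(Nc2cc(NC(=O)Nc3cc(OC)cc(OC)c3)ncn2)cc1`, gives 50.1%. Compound 2 sits at the end of this set, but its separation from compound 1 and from compound 3 lies within the usual scatter, so the three numbers cannot be told apart with confidence.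

Among the compounds with values here, the one step between two compounds that differ in a single place, a number 2.4 percentage points higher from compound 1 to compound 3 (within the scatter), is within the scatter and touches the aryl group on the other side of the shared core, not the side that changes here.

The next compound, compound 4, `COc1ccc(F)cc1Nc1cc(NC(=O)Nc2c(Cl)cccc2Cl)ncn1`, differs from compound 2 by 5-fluoro-2-methoxyphenyl in place of 3-fluoro-4-methylphenyl on a nitrogen on an aromatic ring. Within the data shown here, no measured step bears on this exchange: the only aryl change seen so far sits on the other nitrogen and gave no movement beyond the scatter. There is therefore no basis to expect a step beyond the scatter in this assay in either direction.

Compound 4 is expected to give about 42% in this assay, with a range from 26% to 58%, that is a step of a number 1.3 percentage points higher from compound 2 to compound 4 (within the scatter) that is expected to remain within the scatter.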

Compound 4, a percentage reported as inhibition, at one concentration (the size of the read-out at that concentration, not a potency): 31.3%
For compound 4 the middle estimate is 10.7 percentage points above the measured one, within the range that was stated.
By their numbers in this assay, from the lowest: compounds 4, 2, 1 and 3 (each within the scatter of the next, the first and the last beyond it).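

In this assay, within the data shown here, the exchange of 3-fluoro-4-methylphenyl for 5-fluoro-2-methoxyphenyl on a nitrogen on an aromatic ring gives a number 9.4 percentage points lower from compound 2 to compound 4 (within the scatter) and is the first reading at this position. It shows that this aryl group can be replaced by one with a different set of substituents, a methoxy group among them, without a step beyond the scatter, although the step lies much further from zero than the only earlier one, a number 2.4 percentage points higher from compound 1 to compound 3 (within the scatter), which sits on the other side of the shared core. Nothing measured alongside these numbers bears on the size of this step.

Among these compounds, the pair leaves open what the methoxy group and the fluorine each contribute, as the two aryl groups differ in more than one substituent and only this single pair reads this position. Also open, as far as these compounds go, is whether an aryl group on this nitrogen carrying a morpholine or a carboxylic acid would give a step beyond the scatter in this assay in either direction.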